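A few compounds are considered here, and "the series" means these few. Any claim that something is new, unique, unknown or untested is made for them only; others in the source may bear on it.

Measured compounds in an ADME assay on MT4 cells (Homo sapiens) for cytotoxicity; on this read-out higher numbers stand for lower toxicity in this test and lower numbers for higher toxicity in this test:
compound 1, `O=C(CSc1snnc1-c1ccc(Cl)cc1Cl)Nc1ccccc1F`: 19500 nM
compound 2, `COc1ccc(-c2nnsc2SCC(=O)Nc2ccccc2F)cc1`: > 332000 nM
compound 3, `O=C(CSc1snnc1-c1ccccc1)Nc1ccccc1Cl`: > 345000 nM

For compound 3 the value is a limit of this assay and not a number. For compound 2 the value is likewise a limit of this assay and not a number. Compound 3 thus stands at the non-toxic end of what the three measured compounds show, alongside the limit for compound 2 (the limit of > 345000 nM in this assay, at which 1 of the 3 values shown sits). Compound 1 is the only one of the three with a number.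

The unmeasured compound 4, `O=C(CSc1snnc1-c1ccccc1)Nc1ccccc1F`, differs from compound 3 in one place: fluoro in place of chloro on an aromatic carbon.

Among the measured compounds shown here, the only measured step, an at least 17-fold higher number from compound 1 to compound 2 (1.23 log units; beyond the scatter), concerns a different change and so does not bear on the step from compound 3 to compound 4. Compounds 1 and 2 both carry the 2-fluorophenyl group that enters in compound 4, and compound 2 reaches a limit of this assay with it, so the fluoro group is compatible with a value at a limit. For the measured compounds named here, no measured pair shows the chloro-to-fluoro change itself.

Compound 4 is therefore expected to show no step beyond the scatter, an at least 1.1-fold lower number from compound 3 to compound 4 (0.06 log units; that floor lies within the scatter), and is estimated at 300000 nM, between 100000 nM and 400000 nM.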

Compound 4, half-maximal cytotoxic concentration: > 361000 nM
Compound 4 ended at the assay's limit (the forecaster's own chance of this, stated with the estimate: 65%); middle value at least 1.2-fold (0.08 log units) away from the limit.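

In this assay compound 4 gives > 361000 nM as a limit of the assay and not a number. Among the compounds shown here, the one step that can be read is an at least 18-fold higher number from compound 1 to compound 4 (1.26 log units; beyond the scatter) with phenyl in place of 2,4-dichlorophenyl, and it runs the same way as an at least 17-fold higher number from compound 1 to compound 2 (1.23 log units; beyond the scatter) with 4-methoxyphenyl in that place. For the compounds shown here, the steps from compound 3 to compound 4 and from compound 2 to compound 4 cannot be read, each joining two limits, so 2-chlorophenyl to 2-fluorophenyl has no size here and shows only that both groups go with a limit of this read-out.

From the compounds shown here alone, it remains open whether a single chloro on the phenyl of compound 1 would be enough to bring a number like that of compound 1, and what number lies behind the limit of compound 4. Going by these compounds, whether an amine or a carboxylic acid in the place of the fluoro would still give a limit in this assay also stays open.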